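The compounds below may be only part of what the source reports. "The series", "measured", "known", "first", "only" and "open" are said of these compounds alone.

Measured so far in a functional assay on A498 cells (Homo sapiens) for inhibition, read by sulforhodamine B assay, with a stated time of 48 h; on this read-out lower numbers stand for stronger inhibition of growth and higher numbers for weaker inhibition of growth:
Compound 1 `CCOC(=O)[C@H](CCC(=O)O)NC(=O)c1ccc(CNc2nc3cc(N)cc(N)c3nc2-c2ccccc2)cc1`: for compound 1 the assay reports only a limit, not a number, < 100000 nM.
Compound 2 `Nc1cc(N)c2nc(-c3ccccc3)c(NCc3ccc(Cl)c(Cl)c3)nc2c1`: compound 2 gives 32400 nM.
Compound 3 `COc1cc(CNc2nc3cc(N)cc(N)c3nc2-c2ccccc2)cc(OC)c1OC`: compound 3 gives 14800 nM.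

Of the two actual numbers, compound 2 stands at the higher one; compound 3 sits lower by a margin beyond the usual scatter. The shared core is kept throughout, and the compounds differ only in the group hanging from the benzylic carbon.

Compound 4 `COc1ccc(CNc2nc3cc(N)cc(N)c3nc2-c2ccccc2)cc1` is the next member: 4-methoxyphenyl in place of 3,4-dichlorophenyl on a saturated chain carbon bound to a nitrogen on an aromatic ring. Among the compounds with values here, no pair of measured compounds differs in a single place, so the size of this step cannot be read from a measured precedent. What the numbers do show is that compound 3, which also carries methoxy on that ring, gives a lower number than compound 2 in this assay. On that basis a modest move toward stronger inhibition is expected, a step from compound 2 to compound 4 of about a 1.6-fold lower number from compound 2 to compound 4 (0.21 log units; within the scatter), though a result within the scatter of compound 2 would not surprise. Compound 4 is accordingly estimated at 20000 nM in this assay, with a range from 7000 nM to 60000 nM.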

Compound 4, concentration for total growth inhibition: < 100000 nM
Compound 4 was reported as a limit; the forecaster's own chance of this, stated with the estimate: 15%; the middle value is on the limit's open side.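

In this assay, within the data shown here, compound 4 gives only a limit of < 100000 nM and so no step from compound 2 to compound 4 can be read: the limit of < 100000 nM in this assay, at which 2 of the 4 values shown sit. The compounds shown leave open whether 4-methoxyphenyl in place of 3,4-dichlorophenyl changes growth inhibition at all.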